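Amide to ester on a shared core: an untested step

The source may report more compounds than this note shows. Statements on the series, on what has been measured and on what is new or still open speak of the compounds shown alone.

Measured in an assay on membranes from CHO cells for displacement of a labelled ligand from adenosine receptor A1 (Homo sapiens), read by scintillation counting, with a stated time of 60 min, tested at 1 uM; on this read-out lower numbers stand for less inhibition and higher numbers for more inhibition at the one concentration tested (going by the name of the read-out):
compound 1 `CC1=C(C(=O)NC(C)C)C(c2ccoc2)NC(=O)N1` gives 1%
compound 2 `CC1=C(C(=O)NC(C)C)C(c2cccs2)NC(=O)N1` gives 2%
compound 3 `CC1=C(C(=O)NC(C)C)C(c2ccsc2)NC(=O)N1` gives 8%

In this assay compound 2 gives 2%, a number that sits apart from the other two only within the usual scatter: a number 1 percentage points higher from compound 1 to compound 2 (within the scatter) and a number 6 percentage points higher from compound 2 to compound 3 (within the scatter). Compound 4 `CC1=C(C(=O)OCC2CC2)C(c2cccs2)NC(=O)N1` differs from compound 2 in one place: cyclopropylmethoxy in place of isopropylamino on a carbonyl carbon. None of the three measured steps touches this carbonyl carbon; each of them, a number 1 percentage points higher from compound 1 to compound 2 (within the scatter), a number 7 percentage points higher from compound 1 to compound 3 (within the scatter) and a number 6 percentage points higher from compound 2 to compound 3 (within the scatter), changes only the aromatic ring on the saturated ring carbon and stays within the scatter. There is therefore no measured guide for this change, and the step of a number 2 percentage points higher from compound 2 to compound 4 (within the scatter) is expected to stay within the scatter. Compound 4 is estimated at 4%, in a range of -6% to 18%.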

Compound 4, a percentage reported as inhibition, at one concentration (the size of the read-out at that concentration, not a potency): 23%
Compound 4: the middle estimate sits 19 percentage points below what was measured; the measured number lies above the stated range.
By their numbers in this assay, from the lowest: compounds 1, 2 and 3 (each within the scatter of the next); then compound 4.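

In this assay, the carbonyl carbon is the first place shown where a single change moves the number beyond the scatter (a number 21 percentage points higher from compound 2 to compound 4 (beyond the scatter)), whereas the aromatic ring swaps stayed within it. The new group also removes a hydrogen-bond donor and brings in a three-membered ring. Nothing available explains the rise.

Still open, as far as these compounds go, is which part of the change matters, the oxygen or the ring; isopropoxy or cyclopropylmethylamino on the same carbonyl carbon would separate them. From the compounds shown here alone, whether the step carries over to the furan-3-yl and thiophen-3-yl partners is also open.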